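The source may report more compounds than this note shows. Statements on the series, on what has been measured and on what is new or still open speak of the compounds shown alone.

Notes on the series. Compound 1 `O=C1C(Nc2ccccc2)=CC(=O)c2c1nc1n2[C@H]2OC[C@@H](O)[C@H]2OC1`, compound 2 `Cc1ccc(NC2=CC(=O)c3c(nc4n3[C@H]3OC[C@@H](O)[C@H]3OC4)C2=O)cc1` and compound 3 `O=C1C(N2CCCC2)=CC(=O)c2c1nc1n2[C@H]2OC[C@@H](O)[C@H]2OC1` share one core and differ only in the group on the double-bonded ring carbon. Going by the values given here, in a functional assay on HeLa cells (Homo sapiens) for inhibition, read by sulforhodamine B assay (on this read-out lower numbers stand for stronger inhibition and higher numbers for weaker inhibition), compound 2 gives 6590 nM, the only plain number among the three. For compound 1 this assay reports only a limit, > 8000 nM. For compound 3 likewise only a limit is reported, > 16000 nM. Compound 2 therefore stands as the sole measured point, the two further values being limits, the limit of > 8000 nM in this assay, at which 1 of the 3 values shown sits, and (the limit of > 16000 nM in this assay, at which 1 of the 3 values shown sits).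

Compound 4 `CCCc1ccc(NC2=CC(=O)c3c(nc4n3[C@H]3OC[C@@H](O)[C@H]3OC4)C2=O)cc1` follows from compound 2 by a single change: ethyl in place of hydrogen on a saturated chain carbon bound to an aromatic carbon. Among the compounds with values here, the one measured step that concerns the same part of the molecule is an at least 1.2-fold lower number from compound 1 to compound 2 (0.08 log units; that floor lies within the scatter), whose size the limit on compound 1 leaves unreadable. The step of an at least 2.4-fold higher number from compound 2 to compound 3 (0.38 log units; beyond the scatter) replaces the whole (4-methylphenyl)amino group and says nothing about chain length. Within the data shown here, no measured step thus gives ground to expect a shift beyond the scatter in this assay; a modest move either way remains open. Compound 4 is expected near 5500 nM, within 2000 nM to 15000 nM, which means an expected step of a 1.2-fold lower number from compound 2 to compound 4 (0.08 log units; within the scatter).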

Compound 4, half-maximal inhibitory concentration: 6030 nM
Beside the measured number, compound 4's estimate is 1.1-fold (0.04 log units) below it; low and high end bracket the measured number.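

In this assay, the change from 4-methylphenyl to 4-propylphenyl gives a 1.1-fold lower number from compound 2 to compound 4 (0.04 log units; within the scatter), the only step shown that falls on the saturated chain carbon bound to an aromatic carbon. Adding ethyl at this place therefore leaves the number within the scatter, which the earlier compounds could not show, since their steps changed the aromatic carbon or replaced the whole amino group. Propyl in place of hydrogen on the aromatic carbon reads an at least 1.3-fold lower number from compound 1 to compound 4 (0.12 log units; that floor lies within the scatter), and this figure is only a floor set by a limit: the limit of > 8000 nM in this assay, at which 1 of the 4 values shown sits.

From the compounds shown here alone, whether a longer chain such as hexyl would also stay within the scatter at this place remains open. Also open, going by these compounds, is whether a propyl chain ending in an amine or a carboxylic acid would move the number beyond it.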